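The source may hold more compounds than are shown below. What is called first, only, known or untested is meant among the compounds shown, and "the series" means these compounds.

Two compounds of this study share the same core and have been measured so far. Compound 1 `CCCCCCOc1ccc2[nH]c(-c3ccccc3)c(C3=C(Br)C(=O)NC3=O)c2c1` and compound 2 `CCOc1ccc2[nH]c(-c3cccc(OC)c3)c(C3=C(Br)C(=O)NC3=O)c2c1` differ in more than one place, so only their two numbers can be set side by side. In a physicochemical assay for lipophilicity (on this read-out higher numbers stand for higher lipophilicity and lower numbers for lower lipophilicity), compound 1 gives 4.08. In this assay compound 2 gives 2.97, the lowest of the two numbers, and compound 1 stands beyond the scatter higher.

The step under consideration leads from compound 2 to compound 3 `CCCCCCOc1ccc2[nH]c(-c3cccc(OC)c3)c(C3=C(Br)C(=O)NC3=O)c2c1`, which has not yet been measured in this assay. The change is butyl in place of hydrogen on a saturated chain carbon, two bonds along the chain from an oxygen on an aromatic ring. Among the measured compounds shown here, no measured pair shows this exact change. Still, compound 1 with 4.08 carries the same hexyloxy chain that compound 3 would gain, which supports the expectation of a clear rise: the step from compound 2 to compound 3 in this assay is expected to be a number 1.13 log units higher from compound 2 to compound 3 (beyond the scatter). For compound 3 a value of 4.1 is estimated, within a range from 3.6 to 4.7.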

Compound 3, partition coefficient: 3.92
Compound 3: the middle estimate sits 0.18 log units above what was measured; the range from low to high includes it.
By their numbers in this assay, from the lowest: compound 2; then compounds 3 and 1 (each within the scatter of the next).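

In this assay, among the compounds shown here, butyl in place of hydrogen on a saturated chain carbon, two bonds along the chain from an oxygen on an aromatic ring, gives a number 0.95 log units higher from compound 2 to compound 3 (beyond the scatter) and is the first step read directly at this position, where ethoxy becomes hexyloxy. With hexyloxy in place on both compounds, methoxy in place of hydrogen on an aromatic carbon gives a number 0.16 log units lower from compound 1 to compound 3 (within the scatter) and so leaves compound 1 and compound 3 within the scatter of each other. Nothing measured here accounts for the size of either step.

From the compounds shown here alone, whether a longer chain such as octyloxy, or a chain ending in an amine or a carboxylic acid, would carry the trend further at this position stays open. Going by these compounds, the methoxy step is read only with hexyloxy in place, so its size with ethoxy stays open too.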